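The source may report more compounds than this note shows. Statements on the series, on what has been measured and on what is new or still open speak of the compounds shown alone.

Measured compounds:

- compound 1, `CO[C@]1(c2cnc(Sc3ccc(/C(C)=N/O)cc3)s2)CCO[C@@H](C)C1`, gives 40 nM in a functional assay (blood) for inhibition, with Homo sapiens as the target; a higher number here means a weaker inhibitor, a lower number a stronger inhibitor
- compound 2, `COC(=O)c1cc(CO/N=C(\C)c2ccc(Sc3cc(F)cc(C4CCOCC4)c3)cc2)on1`, gives 100 nM in this assay

Both compounds were tested in this assay, and the two numbers lie apart by more than the usual scatter, so compound 2 stands with the higher of the two numbers and is the weaker inhibitor of the pair. The two compounds differ in several places at once, so nothing can be said about which part of the structure accounts for that gap.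

Compound 3, `COC(=O)C(C)(C)CO/N=C(\C)c1ccc(Sc2cc(F)cc(C3CCOCC3)c2)cc1`, has not yet been measured. It differs from compound 2 in one place: 1-(methoxycarbonyl)-1-methylethyl in place of 3-(methoxycarbonyl)-1,2-oxazol-5-yl on a saturated chain carbon bound to an oxygen on an unsaturated carbon. The change keeps the same ester but trades the five-membered aromatic ring for a short branched chain without any ring.

For the measured compounds named here, no pair of measured compounds that differ in only one place is available, so there is no measured step to lean on. The expectation is a small step from compound 2 to compound 3 in this assay, a 1.5-fold higher number from compound 2 to compound 3 (0.18 log units; within the scatter), towards a slightly higher number, though a result within the scatter would not surprise. Compound 3 is therefore estimated at 150 nM, with a range from 50 nM to 500 nM.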

Compound 3, half-maximal inhibitory concentration: 420 nM
Compound 3: the middle estimate sits 2.8-fold (0.45 log units) below what was measured; measured number inside the range.
By their numbers in this assay, from the lowest: compound 1; then compound 2; then compound 3.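

In this assay, the group at this position clearly matters: replacing 3-(methoxycarbonyl)-1,2-oxazol-5-yl with 1-(methoxycarbonyl)-1-methylethyl gives a 4.2-fold higher number from compound 2 to compound 3 (0.62 log units; beyond the scatter), the first one-place step available here. The ester is present on both sides of the change, so the methoxycarbonyl alone does not keep the inhibition at the level seen for compound 2. What leaves is a five-membered aromatic ring with 2 hetero atoms, and the group goes from 9 heavy atoms and 4 hydrogen-bond acceptors to 7 heavy atoms and 2 hydrogen-bond acceptors, but no measurement shown here explains the weaker inhibition of compound 3.

This single step changes the ring, the branching and the acceptor count all at once, so it cannot show which of them matters. A carboxylic acid in place of the methyl ester, or an unbranched 3-methoxy-3-oxopropyl chain at this place, would help to separate these features, since the first alters only the ester and the second removes the branching while keeping the ester.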